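Adding a methyl to the sulfonyl-bound ring of a kallikrein-7 inhibitor

This account rests on a few compounds, and the source may have more. Where it says the series, first, only, none or still open, it means among the compounds named here.

Measured so far:
compound 1, `CC1=NC(c2cn(Cc3ccc(Cl)cc3)c3ccccc23)CN1`: 22000 nM
compound 2, `CC1=NC(c2cn(S(=O)(=O)c3ccccc3)c3ccc(C)cc23)CN1`: 17000 nM

Both compounds share a core that carries a fused bicyclic ring system with a substituent on its nitrogen. In an assay on isolated protein for inhibition of kallikrein-7 (Homo sapiens), read by fluorescence, with stated times of 10 min and 30 min (a higher number here means a weaker inhibitor, a lower number a stronger inhibitor), compound 1 gives 22000 nM, while compound 2 gives 17000 nM. Compound 2 has the lower of the two numbers, but the gap to compound 1 lies within the scatter of repeated measurements, so the two cannot be told apart and neither can be called the stronger inhibitor.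

The next compound is compound 3, `CC1=NC(c2cn(S(=O)(=O)c3ccccc3C)c3ccc(C)cc23)CN1`. It differs from compound 2 in one place: methyl in place of hydrogen on an aromatic carbon.

Going by the values given here, no comparable step between measured compounds exists here, so there is nothing to lean on for its size. A single methyl added to an aromatic ring is a small change, and the expected step in this assay is none beyond the scatter, in either direction. Compound 3 is therefore estimated at 15000 nM, with a range from 5000 nM to 45000 nM, which means an expected step of a 1.1-fold lower number from compound 2 to compound 3 (0.05 log units; within the scatter).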

Compound 3, half-maximal inhibitory concentration: 1000 nM
Compound 3: middle estimate off by 15-fold (1.18 log units), on the high side; the whole stated range lies above it.
By their numbers in this assay, from the lowest: compound 3; then compounds 2 and 1 (each within the scatter of the next).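

In this assay, turning phenyl into 2-methylphenyl, with a methyl in place of hydrogen on an aromatic carbon ortho to a large group, gives a 17-fold lower number from compound 2 to compound 3 (1.23 log units; beyond the scatter). This shows that the ring on the sulfonyl group is not a place where small edits pass unnoticed: one added carbon, with no ring, no hydrogen-bond donor or acceptor and no net charge, moves the number well beyond the scatter and gives a clearly stronger inhibitor than compound 2. The measurements shown offer no information on why this single methyl has such a large effect.

The compounds shown leave open whether this step is specific to methyl or would also occur with another group at the same place, such as a chlorine atom, a methoxy group or an ethyl group. They also leave open whether the position of the methyl on the ring matters, since a methyl on any other carbon of this ring is not among them, and so a single pair of compounds cannot yet define a trend.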